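The source may report more compounds than this note shows. Statements on the series, on what has been measured and on what is new or still open speak of the compounds shown alone.

Compound 1 `CCCCCC(=O)OC1C(C(O)CO)OC2OC(C)(C)OC21`: 1200000 nM
Compound 2 `CC(C)CC(=O)OC1C(C(O)CO)OC2OC(C)(C)OC21`: 1000000 nM
Compound 3 `CC(C)(C)CC(=O)OC1C(C(O)CO)OC2OC(C)(C)OC21`: 1200000 nM

In a functional assay on K562 cells (Homo sapiens) for inhibition (on this read-out higher numbers stand for weaker inhibition and lower numbers for stronger inhibition), compound 1 gives 1200000 nM, level with compound 3 at the digits shown and within the scatter of compound 2. Compound 4 `CC1(C)OC2OC(C(O)CO)C(OC(=O)C3CCCC3)C2O1` is not yet measured. Its difference from compound 1 is cyclopentyl in place of pentyl on a carbonyl carbon. Among the compounds with values here, two measured steps bear on this change: a 1.2-fold lower number from compound 1 to compound 2 (0.08 log units; within the scatter) and no change at the digits printed from compound 1 to compound 3 (within the scatter). Both lie within the scatter, but neither introduces a ring, so the evidence is indirect. No step beyond the scatter is therefore expected in this assay. The expected step is a 1.2-fold lower number from compound 1 to compound 4 (0.08 log units; within the scatter). For compound 4 the estimated value is 1000000 nM, with an expected range of 500000 nM to 2000000 nM.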

Compound 4, half-maximal inhibitory concentration: 2500000 nM
For compound 4 the middle estimate is 2.5-fold (0.40 log units) below the measured one, and the stated range ends below it.
By their numbers in this assay, from the lowest: compounds 2, 1 and 3 (each within the scatter of the next); then compound 4.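

In this assay the open-chain groups on this carbonyl carbon stay within the scatter of one another, while cyclopentyl stands apart, with a 2.1-fold higher number from compound 1 to compound 4 (0.32 log units; beyond the scatter) and a 2.1-fold higher number from compound 3 to compound 4 (0.32 log units; beyond the scatter) and also a 2.5-fold higher number from compound 2 to compound 4 (0.40 log units; beyond the scatter). At this position, a ring of carbon only therefore separates from pentyl, isobutyl and neopentyl, though each step is modest and weakens inhibition. Nothing available explains this difference. From the compounds shown here alone, whether cyclohexyl or phenyl would follow cyclopentyl remains open. So does the effect of an amine on the acyl chain.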